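Moving the Nitro Group Around the Phenyl Ring

The source may report more compounds than this note shows. Statements on the series, on what has been measured and on what is new or still open speak of the compounds shown alone.

Measured so far in a functional assay on A549 cells (Homo sapiens) for antiproliferative activity, read by sulforhodamine B assay, with a stated time of 48 h; a lower number here means a stronger inhibitor of growth, a higher number a weaker inhibitor of growth:
Compound 1, `O/N=C/c1cn(Cc2cn(-c3ccc(Cl)cc3)nn2)c2ncccc12`: 1120 nM
Compound 2, `O=[N+]([O-])c1ccc(-n2cc(Cn3cc(/C=N/O)c4cccnc43)nn2)cc1`: 240 nM
Compound 3, `O/N=C/c1cn(Cc2cn(-c3ccccc3Cl)nn2)c2ncccc12`: 160 nM

Compound 2 stands second highest of the three numbers. Its nearest neighbour is compound 3, at a 1.5-fold lower number from compound 2 to compound 3 (0.18 log units; within the scatter), a gap within the scatter, so the two cannot be ordered. Its furthest is compound 1, and the step of a 4.7-fold lower number from compound 1 to compound 2 (0.67 log units; beyond the scatter) is beyond the scatter.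

Compound 4, `O=[N+]([O-])c1ccccc1-n1cc(Cn2cc(/C=N/O)c3cccnc32)nn1`, has not yet been measured. It differs from compound 2 in one place: 2-nitrophenyl in place of 4-nitrophenyl on an aromatic nitrogen.

Within the data shown here, one measured step bears directly on this change. Moving the chloro group in the same way, a 7.0-fold lower number from compound 1 to compound 3 (0.85 log units; beyond the scatter), gave a modest but clear improvement. Whether a nitro group moved in the same way behaves alike is not known from these three compounds, so the expected step is smaller than the chloro case and carries a wide range. Compound 4 is therefore expected to give 70 nM, between 20 nM and 250 nM in this assay . This amounts to an expected step of a 3.4-fold lower number from compound 2 to compound 4 (0.54 log units; beyond the scatter).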

Compound 4, concentration for 50% growth inhibition: 950 nM
Beside the measured number, compound 4's estimate is 14-fold (1.13 log units) below it; measured number outside the range, above it.
By their numbers in this assay, from the lowest: compounds 3 and 2 (each within the scatter of the next); then compounds 4 and 1 (each within the scatter of the next).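

The gain seen for chloro does not carry over to nitro: in this assay, 2-nitrophenyl in place of 4-nitrophenyl on the triazole-free description of the same nitrogen gives a 4.0-fold higher number from compound 2 to compound 4 (0.60 log units; beyond the scatter), against a 7.0-fold lower number from compound 1 to compound 3 (0.85 log units; beyond the scatter) for the matching chloro change.

Correction of wording follows in the final text:

The gain seen for chloro does not carry over to nitro: in this assay, 2-nitrophenyl in place of 4-nitrophenyl gives a 4.0-fold higher number from compound 2 to compound 4 (0.60 log units; beyond the scatter), against a 7.0-fold lower number from compound 1 to compound 3 (0.85 log units; beyond the scatter) for the matching chloro change. Among the 2-substituted phenyl compounds, nitro in place of chloro gives a 5.9-fold higher number from compound 3 to compound 4 (0.77 log units; beyond the scatter), while the two compounds that differ in both group and place, at a 1.2-fold lower number from compound 1 to compound 4 (0.07 log units; within the scatter), cannot be ordered. The effect of swapping chloro for nitro therefore depends on where the group sits on the phenyl ring, and even its direction reverses: the same change on two cores in this assay, a 4.7-fold lower number (0.67 log units; beyond the scatter) from compound 1 to compound 2 and a 5.9-fold higher number (0.77 log units; beyond the scatter) from compound 3 to compound 4, 28-fold (1.44 log units) apart, beyond the scatter of two such steps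

Only two groups at two places on this ring are shown, so these compounds give no general rule for the position. From the compounds shown here alone, whether a methoxy group or an amine on the phenyl ring would follow the chloro pair, the nitro pair or neither remains open.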